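Morpholine-free core, same methyl step: expected effect

The compounds below may be only part of what the source reports. "The series", "measured", "known", "first", "only" and "open" are said of these compounds alone.

In a functional assay on the whole organism (strain Swiss) with Mus musculus as the target, in the maximal electroshock model, with a stated time of 1 h, at a dose of 300 mg/kg by the intraperitoneal route (on this read-out higher numbers stand for a stronger effect at the one dose given and lower numbers for a weaker effect), compound 1 `CCC(C(=O)N1CCN(c2cccc(F)c2)CC1)N1C(=O)CCC1=O` gives 75%, and compound 2 `CC(C(=O)N1CCN(c2cccc(F)c2)CC1)N1C(=O)CCC1=O` gives 75%. The step of no change at the digits printed from compound 2 to compound 1 (within the scatter) shows that adding a carbon here leaves the result where it was. The change is methyl in place of hydrogen on a saturated chain carbon, two bonds along the chain from an amide-type nitrogen in a ring and a carbonyl carbon. Compound 3 `CC(C(=O)N1CCOCC1)N1C(=O)CCC1=O` carries a different ring on the amide side; the difference between the two cores is not broken down here. In this assay compound 3 gives 0%, the lowest of the three numbers.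

Compound 4 `CCC(C(=O)N1CCOCC1)N1C(=O)CCC1=O` is built from compound 3 by the same change, (methyl in place of hydrogen on a saturated chain carbon, two bonds along the chain from an amide-type nitrogen in a ring and a carbonyl carbon). Because the step of no change at the digits printed from compound 2 to compound 1 (within the scatter) stayed within the scatter, the same change is expected to move little on the core of compound 3 as well; because compound 3 gives 0%, the starting point is already the lowest of the three numbers. The expected step is a number 10 percentage points higher from compound 3 to compound 4 (within the scatter). Compound 4 is therefore estimated at 10%, most likely between 0% and 40%, with the only real doubt being whether the different core responds to the methyl in its own way.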

Compound 4, a percentage reported as activity, at one dose (the size of the read-out at that dose, not a potency): 0%
Compound 4: the middle estimate sits 10 percentage points above what was measured; measured number inside the range.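

In this assay, putting methyl in place of hydrogen on the saturated chain carbon gives no change at the digits printed from compound 3 to compound 4 (within the scatter). Set beside the same change on the core of compound 1, the two steps agree, so on both cores shown the methyl leaves the read-out where it was: the same change on two cores in this assay, no change at the digits printed (within the scatter) from compound 2 to compound 1 and no change at the digits printed (within the scatter) from compound 3 to compound 4, 0 percentage points apart, within the scatter of two such steps

This does not show that the change would behave the same way on every core, since two cores are a small sample, and on the core of compound 3 the test is a weak one: compound 3 gives 0% and compound 4 gives 0%, so at this one dose there is no effect for the methyl to take away.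

The compounds shown leave open what a longer chain, such as propyl, or a phenyl group would do at this same carbon. They also leave open whether an amine or a carboxylic acid placed there would move the read-out on either core.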